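The source may hold more compounds than are shown below. What is called first, only, known or untested is meant among the compounds shown, and "the series" means these compounds.

Of the compounds shown here, three sharing one core have been measured in a physicochemical assay for solubility, read by HPLC, using the shake flask method, measured as kinetic solubility, with a stated time of 2 h, at pH 7.4; a higher number here means a more soluble compound, a lower number a less soluble compound. Compound 1 `Cc1cc(NCc2ccccn2)n2ncc(-c3cccc(F)c3)c2n1` gives 5000 nM. Compound 2 `Cc1cc(NCc2ccccn2)n2ncc(-c3ccco3)c2n1` gives 48800 nM. Compound 3 `Cc1cc(NCc2ccccn2)n2ncc(-c3ccc(O)cc3)c2n1` gives 10900 nM, the second highest of the three numbers; its nearest neighbour is compound 1 and its furthest is compound 2, as a 2.2-fold higher number from compound 1 to compound 3 (0.34 log units; beyond the scatter) and a 4.5-fold lower number from compound 2 to compound 3 (0.65 log units; beyond the scatter) show. Compound 4 `Cc1cc(NCc2ccccn2)n2ncc(-c3cccc(N(C)C)c3)c2n1` differs from compound 3 in one place: 3-(dimethylamino)phenyl in place of 4-hydroxyphenyl on an aromatic carbon. Going by the values given here, no measured step brings in a 3-(dimethylamino)phenyl, so the guide is only how much changing the group on this carbon has moved this assay so far, at most a 9.8-fold higher number from compound 1 to compound 2 (0.99 log units; beyond the scatter). A modest shift is therefore expected, in an uncertain direction. Compound 4 is estimated at 8000 nM, with a range from 2500 nM to 25000 nM. This amounts to an expected 1.4-fold lower number from compound 3 to compound 4 (0.13 log units; within the scatter).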

Compound 4, solubility: 94600 nM
For compound 4 the middle estimate is 12-fold (1.07 log units) below the measured one; measured number above the stated range.
By their numbers in this assay, from the lowest: compound 1; then compound 3; then compounds 2 and 4 (each within the scatter of the next).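

In this assay, a phenyl group on this aromatic carbon can stand level with the furan-2-yl, as the step within the scatter shows (a 1.9-fold higher number from compound 2 to compound 4 (0.29 log units; within the scatter)). High numbers at this position are therefore not confined to the furan-2-yl, and the substituent on the phenyl ring matters greatly, with an 8.7-fold higher number from compound 3 to compound 4 (0.94 log units; beyond the scatter) and a 19-fold higher number from compound 1 to compound 4 (1.28 log units; beyond the scatter) both beyond the scatter. No evidence is at hand to explain these differences.

Still open, going by these compounds, is whether the dimethylamino group itself is needed, or whether a phenyl ring carrying a morpholine or a carboxylic acid in its place would give a similar number.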